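From Methoxy to Trifluoromethoxy: Expecting Compound 3

The source may hold more compounds than are shown below. What is called first, only, known or untested is meant among the compounds shown, and "the series" means these compounds.

Compound 2 `COc1ccc(/C=C/c2cc(=O)c3c(OC)cc(OC)cc3o2)cc1` was tested in a functional assay on SKHep cells (Homo sapiens) for antiproliferative activity, read by MTT assay, with a stated time of 12 h; a higher number here means a weaker inhibitor, a lower number a stronger inhibitor. In this assay compound 2 gives only a limit of > 40000 nM, not a number. Its close relative compound 1 `COc1cc(OC)c2c(=O)cc(/C=C/c3ccc(Cl)cc3)oc2c1` differs from it only by carrying chloro where compound 2 carries methoxy, and in this assay compound 1 gives 26900 nM. The step of an at least 1.4-fold higher number from compound 1 to compound 2 (0.17 log units; that floor lies within the scatter) rests on the limit of > 40000 nM in this assay, at which 1 of the 2 values shown sits, and so fixes only a floor on how much weaker the methoxy compound is.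

Compound 3 `COc1cc(OC)c2c(=O)cc(/C=C/c3ccc(OC(F)(F)F)cc3)oc2c1` arises from compound 2 by the change (trifluoromethyl in place of methyl on an oxygen on an aromatic ring), so the methoxy becomes trifluoromethoxy. Going by the values given here, no measured step covers this change; the one measured step, an at least 1.4-fold higher number from compound 1 to compound 2 (0.17 log units; that floor lies within the scatter), concerns chloro against methoxy and cannot be carried over. Both measured compounds sit at the weak end of this assay, so weak inhibition is expected for compound 3 as well. The expected step is an at least 1.1-fold lower number from compound 2 to compound 3 (0.05 log units; that floor lies within the scatter), too small to assign a direction beyond the scatter. Compound 3 is therefore expected to give about 35000 nM, within 15000 nM to 80000 nM, with a real chance that this assay again reports only a limit.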

Compound 3, half-maximal inhibitory concentration: 12500 nM
Beside the measured number, compound 3's estimate is 2.8-fold (0.45 log units) above it; the whole stated range lies above it.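

Putting trifluoromethoxy in place of chloro on the aromatic carbon gives a 2.2-fold lower number from compound 1 to compound 3 (0.33 log units; beyond the scatter), which makes compound 3 the strongest of the three and shows that the group at this place can move the result beyond the scatter, something the earlier floor alone could not establish. Within the oxygen-linked pair, trifluoromethyl in place of methyl gives an at least 3.2-fold lower number from compound 2 to compound 3 (0.50 log units; beyond the scatter), so the change from methoxy to trifluoromethoxy matters here even though the two groups differ only in what sits on that oxygen. The true size of that step stays unknown, since compound 2 carries a limit and not a number: the limit of > 40000 nM in this assay, at which 1 of the 3 values shown sits.

On these data alone, still, all three compounds share one core and vary only at this place, so it remains open how an amine, a carboxylic acid or a longer chain such as ethoxy would compare there, and whether trifluoromethyl set directly on the aromatic carbon would match trifluoromethoxy. These values also cannot tell whether the same order would hold on a different core or in other cells.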